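Carbonyl aryl swap: thiophene replaces dimethoxyphenyl

The source may report more compounds than this note shows. Statements on the series, on what has been measured and on what is new or still open speak of the compounds shown alone.

Among the measured compounds shown here, the three compounds measured so far share one core. Compound 1 `COc1ccc(-c2cc3ccccc3nc2/C=C/C(=O)c2ccccc2)cc1` gives 860 nM in a functional assay on MDA-MB-231 cells (Homo sapiens) for antiproliferative activity, read by XTT assay, with a stated time of 72 h (on this read-out higher numbers stand for weaker inhibition and lower numbers for stronger inhibition), and compound 2 `COc1ccc(-c2cc3ccccc3nc2/C=C/C(=O)c2ccc(F)cc2)cc1` gives 830 nM. Compound 3 `COc1ccc(-c2cc3ccccc3nc2/C=C/C(=O)c2ccc(OC)cc2OC)cc1` gives 3210 nM, the highest number of the three, its position set by a 3.7-fold higher number from compound 1 to compound 3 (0.57 log units; beyond the scatter) and by a 3.9-fold higher number from compound 2 to compound 3 (0.59 log units; beyond the scatter). Compound 4 `COc1ccc(-c2cc3ccccc3nc2/C=C/C(=O)c2cccs2)cc1` carries thiophen-2-yl in place of 2,4-dimethoxyphenyl on a carbonyl carbon. For the measured compounds named here, no measured step brings in a thiophene, so only the two steps into compound 3 bear on this change: both show that putting the 2,4-dimethoxyphenyl on the carbonyl carbon raised the number modestly, and taking it away again is expected to undo that. Compound 4 is therefore expected to move back down, estimated at 900 nM (range 400 nM to 2500 nM), an expected step of a 3.6-fold lower number from compound 3 to compound 4 (0.55 log units; beyond the scatter).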

Compound 4, half-maximal inhibitory concentration: 410 nM
Compound 4: the middle estimate sits 2.2-fold (0.34 log units) above what was measured, within the range that was stated.
By their numbers in this assay, from the lowest: compound 4; then compounds 2 and 1 (each within the scatter of the next); then compound 3.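

On the carbonyl carbon, the thiophen-2-yl does more than remove the rise seen with the 2,4-dimethoxyphenyl, giving a 7.8-fold lower number from compound 3 to compound 4 (0.89 log units; beyond the scatter). It also gives lower numbers than the phenyl and the 4-fluorophenyl, with a 2.1-fold lower number from compound 1 to compound 4 (0.32 log units; beyond the scatter) and a 2.0-fold lower number from compound 2 to compound 4 (0.31 log units; beyond the scatter), so a five-membered aromatic ring with a sulfur atom is the best of the four groups here. No measured evidence accounts for this result.

Open, from the compounds shown here alone, is whether the gain is specific to thiophen-2-yl or extends to furan-2-yl or thiophen-3-yl. Also open, going by these compounds, is how a thiophen-2-yl carrying an amine or a carboxylic acid would behave.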